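The source may report more compounds than this note shows. Statements on the series, on what has been measured and on what is new or still open speak of the compounds shown alone.

Compound 3 `O=c1c(C2N=C(c3ccccc3)SS2)coc2cc(Cl)ccc12` is the parent of the step followed here. In a functional assay on IMR-32 cells (Homo sapiens) for inhibition, read by sulforhodamine B assay, with a stated time of 48 h, tested at 100 uM (a lower number here means less inhibition of growth, a higher number more inhibition of growth at the concentration tested), compound 3 gives 53%. Two further compounds share its core. Compound 1 `Cc1ccc2occ(C3N=C(c4ccccc4)SS3)c(=O)c2c1` gives 53% in this assay, and compound 2 `O=c1c(C2N=C(c3ccccc3)SS2)coc2ccc(F)cc12` gives 75%. Compound 3 thus stands level with compound 1 at the digits reported, the two together forming the lower pair of the three numbers, while compound 2 stands higher than both. Among the compounds with values here, the only measured step between neighbours is a number 22 percentage points higher from compound 1 to compound 2 (beyond the scatter), a swap of one substituent on the aromatic ring.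

Compound 4 `O=c1c(C2N=C(c3ccccc3)SS2)coc2ccccc12` arises from compound 3 by hydrogen in place of chloro on an aromatic carbon. Within the data shown here, no measured step replaces a substituent at this place with hydrogen. The step from compound 1 to compound 2 bears on it only as a rough guide to how much a single change on this ring can move this assay. Given that compound 1 and compound 3, with different groups on the ring, come out level, an unsubstituted ring is expected to land near them, and the step of a number 4 percentage points higher from compound 3 to compound 4 (within the scatter) is expected to be small. Compound 4 is therefore estimated at 57%, with a range from 40% to 75%.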

Compound 4, percent growth inhibition at one concentration: 82%
Compound 4: the middle estimate sits 25 percentage points below what was measured; measured number outside the range, above it.
By their numbers in this assay, from the lowest: compounds 1 and 3 (each within the scatter of the next); then compounds 2 and 4 (each within the scatter of the next).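

In this assay the chloro group on this aromatic carbon proves dispensable for growth inhibition, since replacing it with hydrogen gives a number 29 percentage points higher from compound 3 to compound 4 (beyond the scatter) and the two are not interchangeable here. The unsubstituted compound also separates from the methyl compound, with a number 29 percentage points higher from compound 1 to compound 4 (beyond the scatter) in this comparison, while the fluoro compound gives a number 7 percentage points higher from compound 2 to compound 4 (within the scatter) on the same kind of change, so among the three groups replaced by hydrogen, only fluoro leaves the number within the scatter. Nothing at hand explains why hydrogen and fluoro go with the higher pair of numbers and chloro and methyl with the lower pair.

The compounds shown leave open how a larger or differently built group, such as an amine, a methoxy group or a carboxylic acid, would behave on this aromatic carbon, where only chloro and hydrogen can be compared directly. They also leave open whether the pattern holds at concentrations other than the single one tested and whether changes to the phenyl group on the shared core would shift these numbers in the same way.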